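Tertiary amine substituent on the piperidine series: step to compound 3

A few compounds are considered here, and "the series" means these few. Any claim that something is new, unique, unknown or untested is made for them only; others in the source may bear on it.

Measured so far:
- compound 1 `CC(C)=CCCN(C)C1CCN(CCCc2c[nH]c3ccc(-n4cnnc4)cc23)CC1` — 24 nM
- compound 2 `CC(C)=CCN(C)C1CCN(CCCc2c[nH]c3ccc(-n4cnnc4)cc23)CC1` — 41 nM

Going by the values given here, compound 2 stands within the scatter of compound 1 in an assay on CHO cells for displacement of a labelled ligand from 5-hydroxytryptamine receptor 1B (Homo sapiens) (on this read-out higher numbers stand for weaker inhibition and lower numbers for stronger inhibition), the only measured step being a 1.7-fold higher number from compound 1 to compound 2 (0.23 log units; within the scatter). Compound 3 `CC(=O)Nc1ccc(CN(C)C2CCN(CCCc3c[nH]c4ccc(-n5cnnc5)cc34)CC2)cc1` carries 4-acetamidophenyl in place of 2-methylprop-1-en-1-yl on a saturated chain carbon bound to an amine nitrogen. Among the compounds with values here, no measured step bears on a change of this kind; the one known step swaps two short alkenyl chains and stays within the scatter, so it offers no direction. The group entering is larger and brings a donor and an acceptor, which the measured pairs do not probe. For compound 3 the estimate is 60 nM (range 15 nM to 250 nM), an expected step of a 1.5-fold higher number from compound 2 to compound 3 (0.17 log units; within the scatter) with wide uncertainty.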

Compound 3, half-maximal inhibitory concentration: 100 nM
For compound 3 the middle estimate is 1.7-fold (0.22 log units) below the measured one; measured number inside the range.
By their numbers in this assay, from the lowest: compounds 1 and 2 (each within the scatter of the next); then compound 3.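

Going by these compounds alone, on the saturated chain carbon bound to an amine nitrogen, the exchange of an alkenyl chain for 4-acetamidophenyl gives the first step in this assay that clears the scatter, with a 2.4-fold higher number from compound 2 to compound 3 (0.39 log units; beyond the scatter) and, measured against the longer alkenyl chain, a 4.2-fold higher number from compound 1 to compound 3 (0.62 log units; beyond the scatter). Both steps are modest, so this position accepts the much larger aromatic group with only a limited loss of inhibition. No measured evidence accounts for this loss. Going by these compounds, whether it follows from the aromatic ring or from the acetamido group stays open. A plain benzyl or a 4-aminobenzyl group at this place would separate the two.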